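The source may hold more compounds than are shown below. What is called first, only, known or untested is meant among the compounds shown, and "the series" means these compounds.

Measured compounds:
Compound 1 `O=C(/C=C/c1ccc(/C=C/C(=O)c2ccc3ccccc3c2)o1)NO` gives 9930 nM in a functional assay on HepG2 cells (Homo sapiens) for antiproliferative activity, read by MTT assay, with a stated time of 48 h; a lower number here means a stronger inhibitor, a higher number a weaker inhibitor.
Compound 2 `O=C(/C=C/c1ccc(/C=C/C(=O)c2ccc(Cl)cc2)o1)NO` gives 6740 nM.
Compound 3 `O=C(/C=C/c1ccc(/C=C/C(=O)c2cccc(Cl)c2)o1)NO` gives 54500 nM.

Among these three numbers compound 1 stands second highest; compound 2 is nearest, within the scatter, while compound 3 is furthest, beyond the scatter. Among the measured compounds shown here, the only one-place step measured so far is an 8.1-fold higher number from compound 2 to compound 3 (0.91 log units; beyond the scatter), where 3-chlorophenyl replaces 4-chlorophenyl on a carbonyl carbon.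

Compound 4 `COc1ccc2cc(C(=O)/C=C/c3ccc(/C=C/C(=O)NO)o3)ccc2c1` differs from compound 1 by methoxy in place of hydrogen on an aromatic carbon. For the measured compounds named here, no measured step tests a methoxy entering anywhere, nor any change on the fused ring of compound 1; the step from compound 2 to compound 3 shows only that moving a chlorine on the phenyl attached to the carbonyl carbon can shift the number, and says nothing direct about this change. Going by the values given here, with no step that bears on it, the expectation for this assay is no step beyond the scatter, with a wide range either way. Compound 4 is therefore estimated at 9000 nM (range 3000 nM to 30000 nM), an expected step of a 1.1-fold lower number from compound 1 to compound 4 (0.04 log units; within the scatter).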

Compound 4, half-maximal inhibitory concentration: 6220 nM
For compound 4 the middle estimate is 1.4-fold (0.16 log units) above the measured one, and the stated range covers the measured number.
By their numbers in this assay, from the lowest: compounds 4, 2 and 1 (each within the scatter of the next); then compound 3.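

In this assay, methoxy in place of hydrogen on an aromatic carbon of the fused system of compound 1 gives a 1.6-fold lower number from compound 1 to compound 4 (0.20 log units; within the scatter), so this position takes the methoxy with no readable change in the number. Among the compounds shown here, that is the first sign of a substitution leaving the number within the scatter, whereas the only earlier step, the chlorine shift giving an 8.1-fold higher number from compound 2 to compound 3 (0.91 log units; beyond the scatter), lay beyond it. No measurement offers an explanation for this result.

Going by these compounds, whether this carbon stays as undemanding with a different group, such as an amine, a carboxylic acid or a longer ethoxy chain, remains open. Also open, on these data alone, is whether a methoxy on the phenyl of compound 2 would behave as it does here, or would shift the number as moving the chlorine did.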